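A few compounds are considered here, and "the series" means these few. Any claim that something is new, unique, unknown or untested is made for them only; others in the source may bear on it.

Compounds measured so far in an ADME assay on HepG2 2.2.15 cells (Homo sapiens) for cytotoxicity, read by MTT assay; on this read-out higher numbers stand for lower toxicity in this test and lower numbers for higher toxicity in this test:

Compound 1 `C=C1CC[C@@H]2[C@](C)(COC(=O)/C=C/c3ccccc3)[C@H](O)CC[C@@]2(C)[C@@H]1/C=C/C1=CCOC1=O`: 183000 nM
Compound 2 `C=C1CC[C@@H]2[C@](C)(COC(=O)c3cccnc3)[C@H](O)CC[C@@]2(C)[C@@H]1/C=C/C1=CCOC1=O`: 113000 nM
Compound 3 `C=C1CC[C@@H]2[C@](C)(CO)[C@H](OC(=O)/C=C/c3ccccc3)CC[C@@]2(C)[C@@H]1C/C=C1\C=COC1=O`: 179000 nM

Compound 1 and compound 2 share one core and differ at a single place: pyridin-3-yl in place of 2-phenylethenyl on a carbonyl carbon. In this assay that change gives a 1.6-fold lower number from compound 1 to compound 2 (0.21 log units; within the scatter), a step that stays inside the usual scatter of repeated measurements, so the two numbers cannot be told apart with confidence.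

Compound 3 is built from the same atoms as compound 1, joined differently; the difference between the two cores is not broken down here. In this assay compound 3 gives 179000 nM, and compound 1 gives 183000 nM, two numbers that lie within the scatter of each other.

Compound 4 `C=C1CC[C@@H]2[C@](C)(CO)[C@H](OC(=O)c3cccnc3)CC[C@@]2(C)[C@@H]1C/C=C1\C=COC1=O` has not yet been measured. It stands to compound 3 as compound 2 stands to compound 1: pyridin-3-yl in place of 2-phenylethenyl on a carbonyl carbon. The place lines of the two changes read the same word for word, so this is the same change made on the other core. Because the measured pair gave a 1.6-fold lower number from compound 1 to compound 2 (0.21 log units; within the scatter), the corresponding step on the core of compound 3 is expected to be of similar size, that is a 1.5-fold lower number from compound 3 to compound 4 (0.17 log units; within the scatter), and is not expected to leave the scatter. On that basis compound 4 is estimated to give 120000 nM in this assay, with a plausible range from 60000 nM to 240000 nM.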

Compound 4, half-maximal cytotoxic concentration: 337000 nM
For compound 4 the middle estimate is 2.8-fold (0.45 log units) below the measured one, and the stated range ends below it.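

On the core of compound 3, in this assay, putting pyridin-3-yl in place of 2-phenylethenyl on a carbonyl carbon gives a 1.9-fold higher number from compound 3 to compound 4 (0.27 log units; within the scatter), a step that cannot by itself be told apart from repeated measurement of one compound. Set beside the matching step on the core of compound 1, it shows that this change does not carry over between the two cores as one fixed step, since the two steps run in opposite directions and the gap between them is larger than scatter alone would explain: the same change on two cores in this assay, a 1.6-fold lower number (0.21 log units; within the scatter) from compound 1 to compound 2 and a 1.9-fold higher number (0.27 log units; within the scatter) from compound 3 to compound 4, 3.0-fold (0.48 log units) apart, beyond the scatter of two such steps. For the compounds shown here, this does not show why the steps differ or that the core is responsible, and with only two pairs, each within the scatter when read alone, it gives no rule for what the same change would do on any further core.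

The compounds shown leave open how other groups on this carbonyl carbon, such as a saturated 2-phenylethyl chain, a simple methyl group or an amine-bearing chain, would behave on each of the two cores. They also leave open whether a repeat of these four compounds would keep the gap between the two steps, and how the change would read on a third core.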